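From 4-fluorophenyl to 4-chlorophenyl: working notes on the series

The source may report more compounds than this note shows. Statements on the series, on what has been measured and on what is new or still open speak of the compounds shown alone.

Going by the values given here, in a functional assay on B16 cells (Mus musculus) for cytotoxicity, read by CCK-8 assay, with a stated time of 24 h (a lower number here means a stronger inhibitor, a higher number a weaker inhibitor), compound 2 (`COc1ccccc1Oc1c(N)nc(-c2ccc(F)cc2)nc1Cl`) gives 2990 nM as the lowest of the two numbers so far. Among the compounds with values here, compound 1 (`COc1ccc(-c2nc(N)c(Oc3ccccc3OC)c(Cl)n2)cc1`) stands at 47800 nM as the only other measured compound. Compound 3 (`COc1ccccc1Oc1c(N)nc(-c2ccc(Cl)cc2)nc1Cl`) has no number yet. Its change reads chloro in place of fluoro on an aromatic carbon and amounts to chloro in place of fluoro on an aromatic carbon, para to a large group. Within the data shown here, only one measured step bears on that place: a 16-fold lower number from compound 1 to compound 2 (1.20 log units; beyond the scatter) is large and beyond the scatter. Among the measured compounds shown here, it removed methoxy, however, so it sets no size for this swap, and no measured compound carries chloro. A small step with no firm direction is therefore expected in this assay and most likely stays within the scatter. The expected step is a 1.1-fold lower number from compound 2 to compound 3 (0.03 log units; within the scatter) on this reading. Compound 3 is estimated at 2800 nM with an expected range from 900 nM to 9000 nM for now.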

Compound 3, half-maximal inhibitory concentration: 18800 nM
The estimate for compound 3 lay 6.7-fold (0.83 log units) below the measured number, and the stated range ends below it.
By their numbers in this assay, from the lowest: compound 2; then compound 3; then compound 1.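

In this assay this place proves sensitive to the choice of halogen: a 6.3-fold higher number from compound 2 to compound 3 (0.80 log units; beyond the scatter) is a step beyond the scatter, although one heavy atom simply replaces another and the counts of hydrogen-bond donors and acceptors stay the same. Chloro is also set apart from methoxy, with a 2.5-fold lower number from compound 1 to compound 3 (0.41 log units; beyond the scatter) likewise beyond the scatter, so fluoro, chloro and methoxy on this aromatic carbon give three separate levels, running from compound 2 through compound 3 to compound 1. No measurement at hand accounts for this order.

The compounds shown leave open where a hydrogen, an amine, a nitrile or a carboxylic acid at this place would fall relative to these three levels. From the compounds shown here alone, whether the gap between fluoro and chloro persists when another part of the shared core changes also remains open.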